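A few compounds are considered here, and "the series" means these few. Any claim that something is new, unique, unknown or untested is made for them only; others in the source may bear on it.

Working notes on the series. Two compounds have numbers in an assay on blood for inhibition of Polyunsaturated fatty acid 5-lipoxygenase (Homo sapiens); a lower number here means a stronger inhibitor, a higher number a weaker inhibitor. Compound 1, `NC(=O)N(O)CCC#C[C@@H]1CC[C@@H](CN2CCN([C@H](c3ccccc3)c3ccc(Cl)cc3)CC2)O1`, gives 310 nM in this assay. Compound 2, `NC(=O)N(O)CCC#Cc1ccc(CN2CCN([C@H](c3ccccc3)c3ccc(Cl)cc3)CC2)o1`, gives 420 nM in this assay. Compound 1 carries the lowest of the two numbers, and its nearest neighbour is compound 2, whose number is within the scatter of it, so the two are read as indistinguishable on the present data.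

The step of interest goes from compound 1 to compound 3, `NC(=O)N(O)CCC#C[C@H]1CC[C@H](CN2CCN([C@H](c3ccccc3)c3ccc(Cl)cc3)CC2)O1`, which has not been measured in this assay. The change is the two compounds have the same atoms and bonds and differ only in configuration as drawn: 2 of 3 stereo elements differ; a stereocentre at a saturated ring carbon is drawn S in compound 1 and R in compound 3; a stereocentre at a saturated ring carbon is drawn S in compound 1 and R in compound 3. In words: the two compounds have the same atoms and bonds and differ only in configuration as drawn, with two of three stereo elements differing, each a stereocentre at a saturated ring carbon drawn S in compound 1 and R in compound 3. Among the measured compounds shown here, no measured pair differs only in configuration, so the series gives no guide to the size or direction of such a step. The expectation for compound 3 is a step of a 1.5-fold higher number from compound 1 to compound 3 (0.16 log units; within the scatter) in this assay, with no clear direction and a wide uncertainty. Compound 3 is estimated at 450 nM, within a range of 120 nM to 1700 nM.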

Compound 3, half-maximal inhibitory concentration: 510 nM
Compound 3: middle estimate off by 1.1-fold (0.05 log units), on the low side; the measured number falls inside the stated range.
By their numbers in this assay, from the lowest: compounds 1, 2 and 3 (each within the scatter of the next).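

In this assay, this pair gives the series its first reading of a change in configuration alone, and drawing both saturated ring carbons R instead of S gives a step of a 1.6-fold higher number from compound 1 to compound 3 (0.22 log units; within the scatter). On this pair, then, the two ring stereocentres can be inverted together without a step that can be told from repeat measurement, and neither compound 1 nor compound 3 can be ranked above the other. No other change in structure accompanies this step, so it can be referred to configuration alone: the fact that compounds 1 and 3 differ only in the configuration as drawn

The compounds shown leave open what happens when only one of the two ring stereocentres is inverted, and whether the third stereo element, which compounds 1 and 3 share, has any bearing on the number in this assay. They also leave open whether the same insensitivity to ring configuration would hold with a different substituent, such as a fluorine in place of the chlorine, since a single pair cannot show whether the result extends beyond these two compounds.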